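This account rests on a few compounds, and the source may have more. Where it says the series, first, only, none or still open, it means among the compounds named here.

For the measured compounds named here, in a functional assay on MDA-MB-231 cells (Homo sapiens) for antiproliferative activity, read by MTT assay, with a stated time of 72 h (on this read-out higher numbers stand for weaker inhibition and lower numbers for stronger inhibition), compound 1 `CC1=CC[C@H]2[C@H](CC[C@]2(C)O)C(C)(C)[C@@H]1CC[C@H]1[C@]2(C)CC[C@H](OC(=O)c3ccc(Cl)cc3)C(C)(C)O[C@H]2CC[C@@]1(C)O` gives 10300 nM and compound 2 `CC1=CC[C@H]2[C@H](CC[C@]2(C)O)C(C)(C)[C@@H]1CC[C@H]1[C@]2(C)CC[C@H](OC(=O)c3ccc([N+](=O)[O-])cc3)C(C)(C)O[C@H]2CC[C@@]1(C)O` gives 8900 nM, so compound 2 stands level with its only measured neighbour. Compound 3 `CC1=CC[C@H]2[C@H](CC[C@]2(C)O)C(C)(C)[C@@H]1CC[C@H]1[C@]2(C)CC[C@H](OC(=O)c3ccccc3F)C(C)(C)O[C@H]2CC[C@@]1(C)O` differs from compound 2 by 2-fluorophenyl in place of 4-nitrophenyl on a carbonyl carbon. Going by the values given here, the one measured step, a 1.2-fold lower number from compound 1 to compound 2 (0.06 log units; within the scatter), put nitro in place of chloro on an aromatic carbon and stayed within the scatter. Among the compounds with values here, no measured compound carries 2-fluorophenyl, so this evidence is thin, but no shift beyond the scatter is expected in this assay. The expected step is a 1.1-fold higher number from compound 2 to compound 3 (0.05 log units; within the scatter). Compound 3 is estimated at 10000 nM, with an expected range of 5000 nM to 20000 nM.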

Compound 3, half-maximal inhibitory concentration: 28700 nM
For compound 3 the middle estimate is 2.9-fold (0.46 log units) below the measured one; the measured number lies above the stated range.
By their numbers in this assay, from the lowest: compounds 2 and 1 (each within the scatter of the next); then compound 3.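

The carbonyl-linked aryl group is not a silent position in this assay: 2-fluorophenyl brings a 3.2-fold higher number from compound 2 to compound 3 (0.51 log units; beyond the scatter) and a 2.8-fold higher number from compound 1 to compound 3 (0.45 log units; beyond the scatter) even though 4-chlorophenyl and 4-nitrophenyl stand level. For the compounds shown here, the change therefore gives modestly weaker inhibition, the only direction of shift seen at this position so far. Nothing at hand accounts for this shift.

As far as these compounds go, whether the shift belongs to the fluorine itself or to its place on the ring stays open. From the compounds shown here alone, the effect of an amine or a carboxylic acid on the aromatic ring also remains unknown.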